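This account rests on a few compounds, and the source may have more. Where it says the series, first, only, none or still open, it means among the compounds named here.

Compound 2, `O=C(NCc1ccc(CNS(=O)(=O)c2ccccc2)cc1)c1cccnc1`, gives 10 nM in an assay on MDA-MB-231 cells for binding affinity to C-X-C chemokine receptor type 4 (Homo sapiens), read by immunofluorescence and microscopy, with stated times of 10 min and 30 min (a higher number here means that more compound is needed for the effect, a lower number that less compound is needed), the same at the digits shown as compound 3, `Cc1ccc(S(=O)(=O)NCc2ccc(CNC(=O)c3ccccc3Cl)cc2)cc1`, which gives 10 nM; compound 1, `COc1ccc(C(=O)NCc2ccc(CNS(=O)(=O)c3ccc(C)cc3)cc2)cc1`, stands furthest away at 100 nM. Compound 4, `Cc1cccc(C(=O)NCc2ccc(CNS(=O)(=O)c3ccccc3)cc2)c1`, differs from compound 2 in one place: 3-methylphenyl in place of pyridin-3-yl on a carbonyl carbon. Within the data shown here, no measured step changes this exact pair of groups. Among the measured compounds shown here, the only step at the carbonyl carbon, a 10-fold lower number from compound 1 to compound 3 (1.00 log units; beyond the scatter), shows that the aryl group on that carbon can move the number well beyond the scatter, but it swaps different groups. For the measured compounds named here, with no direct precedent, a change of modest size in either direction is possible, and the expected step of a 2.0-fold higher number from compound 2 to compound 4 (0.30 log units; within the scatter) is taken as small. Compound 4 is therefore estimated at 20 nM, within 5 nM to 80 nM.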

Compound 4, effective concentration (reported as EC, without a stated level of effect): 1000 nM
Beside the measured number, compound 4's estimate is 50-fold (1.70 log units) below it; the measured number lies above the stated range.
By their numbers in this assay, from the lowest: compounds 2 and 3 (each within the scatter of the next); then compound 1; then compound 4.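

In this assay the exchange of pyridin-3-yl for 3-methylphenyl on the carbonyl carbon gives a 100-fold higher number from compound 2 to compound 4 (2.00 log units; beyond the scatter) and so shows that a change at this position can also raise the number. Among these compounds, the only earlier step there, a 10-fold lower number from compound 1 to compound 3 (1.00 log units; beyond the scatter) on a different pair of groups, lowered it. This exchange removes the ring nitrogen and adds a methyl group together, and the compounds shown do not separate the two. On these data alone, whether unsubstituted phenyl or pyridin-4-yl on that carbon would stand nearer compound 2 or compound 4 remains open. No evidence bearing on the cause of this step is available.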